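A few compounds are considered here, and "the series" means these few. Any claim that something is new, unique, unknown or untested is made for them only; others in the source may bear on it.

Measured compounds:
Compound 1 `C/C(=N\NC(=O)c1ccc(C(F)(F)F)cc1)c1cnccn1`: 1160 nM
Compound 2 `C/C(=N\NC(=O)c1ccc(O)cc1)c1cnccn1`: 16800 nM
Compound 3 `O=C(NN=C(c1ccccn1)c1ccccn1)c1ccc(O)cc1`: 7530 nM

All three were tested in an ADME assay on cells (Homo sapiens) for antiproliferative activity, read by MTT assay; on this read-out lower numbers stand for stronger inhibition and higher numbers for weaker inhibition. Compound 1 and compound 2 share one core and differ only by trifluoromethyl in place of hydroxy on an aromatic carbon, and that single change gave a 14-fold lower number from compound 2 to compound 1 (1.16 log units; beyond the scatter). Compound 3 carries a different core; how the core of compound 3 differs from that of compound 2 is not broken down here, and the two values can only be set side by side: compound 3 gives 7530 nM, while compound 2 gives 16800 nM.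

Compound 4 `O=C(NN=C(c1ccccn1)c1ccccn1)c1ccc(C(F)(F)F)cc1` has not yet been measured. It stands to compound 3 as compound 1 stands to compound 2: the change is trifluoromethyl in place of hydroxy on an aromatic carbon, the same change, at the same place, as between compound 2 and compound 1. Since that change produced a 14-fold lower number from compound 2 to compound 1 (1.16 log units; beyond the scatter) on the first core, a step of similar direction and size is expected on the second core, estimated as an 11-fold lower number from compound 3 to compound 4 (1.03 log units; beyond the scatter), though a different core may not carry it over in full. Compound 4 is therefore expected in this assay at about 700 nM, most plausibly between 250 nM and 2500 nM.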

Compound 4, half-maximal inhibitory concentration: 240 nM
Beside the measured number, compound 4's estimate is 2.9-fold (0.46 log units) above it; the measured number lies below the stated range.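

In this assay, trifluoromethyl in place of hydroxy on the second core gave a 31-fold lower number from compound 3 to compound 4 (1.50 log units; beyond the scatter) and so repeated the direction of the step seen on the first core. The two steps also agree in size, since the gap between them lies within the scatter: the same change on two cores in this assay, a 14-fold lower number (1.16 log units; beyond the scatter) from compound 2 to compound 1 and a 31-fold lower number (1.50 log units; beyond the scatter) from compound 3 to compound 4, 2.2-fold (0.34 log units) apart, within the scatter of two such steps

So in this series the change carried over from one core to the other without a detectable loss or gain, but this rests on a single pair of cores and says nothing about a third core or about why the number falls.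

Only hydroxy and trifluoromethyl appear at this place on the ring, so the compounds shown leave open what an amine, a carboxylic acid or a methoxy group would give there. They also leave open whether a single fluorine or a chlorine would produce a step of similar size on either core.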